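A few compounds are considered here, and "the series" means these few. Any claim that something is new, unique, unknown or untested is made for them only; others in the source may bear on it.

Compound 1 `O=C(Nc1cccc(Cl)c1)c1cc(Br)cc(Br)c1`: in an assay on isolated protein for inhibition of thiosulfate sulfurtransferase (Homo sapiens), with a stated time of 60 min, in the absence of a further agent (a higher number here means a weaker inhibitor, a lower number a stronger inhibitor), compound 1 gives > 100000 nM, which is a limit of the assay.
Compound 2 `O=C(Nc1cccc(Cl)c1)c1cccc(Br)c1`: in this assay compound 2 gives > 100000 nM, again a limit.
Compound 3 `O=C(Nc1cccc(Cl)c1)c1cccc(Br)c1O`: in this assay compound 3 gives > 100000 nM, also a limit.

Compound 2 therefore stands only at a limit in this assay, with no number of its own, and the two other compounds stand at the same limit, (the limit of > 100000 nM in this assay, at which 3 of the 3 values shown sit). Compound 4 `COc1ccc(Br)cc1C(=O)Nc1cccc(Cl)c1` differs from compound 2 by methoxy in place of hydrogen on an aromatic carbon. The steps that might guide an expectation are a step that the two limits leave unreadable from compound 1 to compound 2 and a step that the two limits leave unreadable from compound 2 to compound 3, but neither size can be read because the limit of > 100000 nM in this assay, at which 3 of the 3 values shown sit, caps every value. So no readable step, in either direction, is available for the change from compound 2 to compound 4. For compound 4 in this assay the estimate is 150000 nM, within 30000 nM to 1000000 nM, meaning an expected step that the limit leaves unreadable from compound 2 to compound 4.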

Compound 4, half-maximal inhibitory concentration: > 100000 nM
Compound 4 was reported as a limit; the forecaster's own chance of this, stated with the estimate: 85%; the middle value is on the limit's open side.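

In this assay compound 4 gives > 100000 nM, again a limit, so no step from compound 2 to compound 4 can be read: the limit of > 100000 nM in this assay, at which 4 of the 4 values shown sit.

The compounds shown leave open which change to the shared core, if any, would give a measurable value in this assay.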